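Methylation of a phenolic hydroxy in a pyrazole urea series

This account rests on a few compounds, and the source may have more. Where it says the series, first, only, none or still open, it means among the compounds named here.

Of the compounds shown here, three from this set have been measured in a functional assay on KM12 cells (Homo sapiens) for inhibition, read by sulforhodamine B assay, with a stated time of 48 h, tested at 0.1 uM; on this read-out lower numbers stand for a stronger effect and higher numbers for a weaker effect at the one concentration tested. Compound 1 `O=C(Nc1cccc(-n2cc(-c3ccncc3)c(-c3cc(O)cc(Cl)c3)n2)c1)Nc1ccc(Cl)c(Cl)c1` carries a 3-chloro-5-hydroxyphenyl group and a 3,4-dichlorophenyl urea, and in this assay compound 1 gives 100%. Compound 2 `COc1cc(Cl)cc(-c2nn(-c3cccc(NC(=O)Nc4ccc(Cl)c(C(F)(F)F)c4)c3)cc2-c2ccncc2)c1` and compound 3 `COc1cc(Cl)cc(-c2nn(-c3cccc(NC(=O)Nc4cc(C(F)(F)F)cc(C(F)(F)F)c4)c3)cc2-c2ccncc2)c1` both carry the 3-chloro-5-methoxyphenyl group in place of the hydroxy-bearing ring, combined with other halogenated phenyl ureas; in this assay compound 2 gives 98% and compound 3 gives 98%. All three numbers sit within the usual scatter of one another, so compound 1 cannot be set apart from compound 2 or compound 3 on these data, and no change among them can be claimed.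

Compound 4 `COc1cc(Cl)cc(-c2nn(-c3cccc(NC(=O)Nc4ccc(Cl)c(Cl)c4)c3)cc2-c2ccncc2)c1` has not yet been measured. It differs from compound 1 in one place: methyl in place of hydrogen on an oxygen on an aromatic ring. The same change is already represented, on other urea partners, by compound 2 and compound 3, whose numbers lie level with that of compound 1. Given the flat picture across the three measured compounds, the step is expected to be none beyond the scatter, with the expected step of a number 2 percentage points lower from compound 1 to compound 4 (within the scatter). Compound 4 is therefore estimated at 98% in this assay, within a range of 88% to 106%.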

Compound 4, a percentage reported as activity, at one concentration (the size of the read-out at that concentration, not a potency): 92%
Compound 4: middle estimate off by 6 percentage points, on the high side; measured number inside the range.
By their numbers in this assay, from the lowest: compounds 4, 2, 3 and 1 (each within the scatter of the next).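

Among the compounds shown here, compound 4 gives the first direct reading of this change. It keeps the 3,4-dichlorophenyl urea of compound 1 and alters only the group on the oxygen on the aromatic ring. In this assay, going from hydroxy to methoxy gives a number 8 percentage points lower from compound 1 to compound 4 (within the scatter) and so shows no change that can be claimed at this position, whereas the earlier comparison of compound 1 with compound 2 and compound 3 also carried different urea partners. With the methoxy group held constant, chloro in place of trifluoromethyl on an aromatic carbon gives a number 6 percentage points lower from compound 2 to compound 4 (within the scatter) on the urea ring, and no measurement shown offers an explanation for either step.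

Going by these compounds, it remains open whether a larger group on that oxygen, such as an ethyl or a longer chain ending in an amine, or a carboxylic acid in place of the hydroxy group, would move the read-out beyond the scatter. A reading at one concentration gives no potency, so these compounds may yet differ at other concentrations.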